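Swapping the trifluorophenyl group on the sulfonyl sulfur

The compounds below may be only part of what the source reports. "The series", "measured", "known", "first", "only" and "open" are said of these compounds alone.

Compound 1 (`CCn1c([C@@H](C)NS(=O)(=O)c2ccc(Cl)cc2)nc2ccc(C(F)(F)F)cc21`) gives > 100 mL.min-1.g-1 in an ADME assay (liver) for metabolic stability, with Liver microsome (Homo sapiens) as the target, read by LC-MS, using microsomes and NADPH, with a stated time of 5 min, at 37 degrees C (a higher number here means faster removal of the compound, a lower number slower removal), and this is a limit of the assay, not a number. Compound 2 (`CCn1c([C@@H](C)NS(=O)(=O)c2ccc(F)cc2)nc2ccc(C(F)(F)F)cc21`) reads 26 mL.min-1.g-1 in this assay and compound 3 (`CCn1c([C@@H](C)NS(=O)(=O)c2c(F)cc(F)cc2F)nc2ccc(C(F)(F)F)cc21`) reads 19 mL.min-1.g-1 on the same scale, two values within the scatter of each other.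

Compound 4 (`CCCn1cc(S(=O)(=O)N[C@H](C)c2nc3ccc(C(F)(F)F)cc3n2CC)c(C)n1`) differs from compound 3 on a sulfonyl sulfur, where a group of 9 heavy atoms (7 carbon, 2 nitrogen; one five-membered aromatic ring with 2 hetero atoms) in place of a group of 9 heavy atoms (6 carbon, 3 fluorine; one six-membered aromatic ring of carbon only), on a sulfonyl sulfur is the whole change. Three measured steps alter the group at this place. Of these, an at least 3.8-fold lower number from compound 1 to compound 2 (0.58 log units; beyond the scatter) and an at least 5.2-fold lower number from compound 1 to compound 3 (0.72 log units; beyond the scatter) lie beyond the scatter, while a 1.4-fold lower number from compound 2 to compound 3 (0.14 log units; within the scatter) lies within it. All three keep a six-membered aromatic ring of carbon only, so none gives a direct size for the entry of a five-membered aromatic ring with 2 hetero atoms.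

The step of an at least 5.2-fold lower number from compound 1 to compound 3 (0.72 log units; beyond the scatter) shows that a change in this group can move the number well beyond the scatter, so a modest rise from compound 3 at 19 mL.min-1.g-1 is expected rather than no shift at all. The estimated change is a 2.0-fold higher number from compound 3 to compound 4 (0.30 log units; within the scatter) and it remains uncertain in size. The estimate for compound 4 is 38 mL.min-1.g-1 with an expected range from 14 mL.min-1.g-1 to 100 mL.min-1.g-1 in this assay once measured.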

Compound 4, intrinsic clearance in microsomes: > 100 mL.min-1.g-1
Compound 4: only a limit was reported; the forecaster's own chance of this, stated with the estimate: 10%; at least 2.6-fold (0.42 log units) between middle value and limit.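

In this assay, within the data shown here, the earlier steps at this position kept a six-membered aromatic ring of carbon only, and the entry of a five-membered aromatic ring with 2 hetero atoms on a sulfonyl sulfur now gives an at least 5.2-fold higher number from compound 3 to compound 4 (0.72 log units; beyond the scatter) and an at least 3.8-fold higher number from compound 2 to compound 4 (0.58 log units; beyond the scatter). This shows that replacing the ring itself can raise the number beyond the scatter, even with 2,4,6-trifluorophenyl and the entering group equal in heavy-atom count, although the entering group adds hydrogen-bond acceptors. The reading for compound 4 is a limit of the assay, so the upper size of both steps stays unknown, and the step involving compound 1, which also stands at a limit, cannot be read: the limit of > 100 mL.min-1.g-1 in this assay, at which 2 of the 4 values shown sit.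

The compounds shown leave open whether the rise belongs to the five-membered ring itself or to the groups it carries, and whether the same ring without its alkyl groups would read lower in this assay. They also leave open how a pyridine ring, or a phenyl ring bearing a carboxylic acid, would read on the sulfonyl sulfur.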